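From chloro to bromo in compound 2

A few compounds are considered here, and "the series" means these few. Any claim that something is new, unique, unknown or untested is made for them only; others in the source may bear on it.

Compound 1 `CCOC[C@H]1C[C@@](CC(C)C)(C(=O)O)N(C(=O)c2ccc(C(C)(C)C)c(OC)c2)[C@H]1c1nccs1`: 5 mL/min/kg
Compound 2 `CC(C)C[C@@]1(C(=O)O)C[C@H](C(N)=O)[C@H](c2nccs2)N1C(=O)c1ccc(C(C)(C)C)c(Cl)c1`: 29 mL/min/kg

In an in vivo ADME assay on the whole organism (plasma, strain Sprague-Dawley) for pharmacokinetics, with Rattus norvegicus as the target, at a dose of 1 mg/kg by the intravenous route (on this read-out higher numbers stand for fast clearance and lower numbers for slow clearance), compound 1 gives 5 mL/min/kg, and compound 2 stands higher of the two at 29 mL/min/kg, a gap beyond the usual scatter. These two compounds differ in more than one place, so their gap does not isolate any single change.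

Compound 3 `CC(C)C[C@@]1(C(=O)O)C[C@H](C(N)=O)[C@H](c2nccs2)N1C(=O)c1ccc(C(C)(C)C)c(Br)c1` has not yet been measured. It departs from compound 2 in one place: bromo in place of chloro on an aromatic carbon. That is bromo in place of chloro on an aromatic carbon. Among the compounds with values here, no measured pair shows this exchange, so the expectation starts from compound 2 at 29 mL/min/kg. The estimated step of a 1.1-fold lower number from compound 2 to compound 3 (0.03 log units; within the scatter) in this assay is expected to stay within the scatter, with no firm direction. For compound 3 the expected value is 27 mL/min/kg, with an estimated range of 14 mL/min/kg to 50 mL/min/kg.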

Compound 3, clearance: 24 mL/min/kg
The estimate for compound 3 lay 1.1-fold (0.05 log units) above the measured number, within the range that was stated.
By their numbers in this assay, from the lowest: compound 1; then compounds 3 and 2 (each within the scatter of the next).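

In this assay, bromo in place of chloro on this aromatic carbon, ortho to a tert-butyl group, gives a 1.2-fold lower number from compound 2 to compound 3 (0.08 log units; within the scatter), so the two halogens cannot be told apart at this position on this read-out. This is the only pair shown that differs in one place, and it gives a reading of this position that the contrast between compound 1 and compound 2 could not provide. Nothing measured here accounts for this result.

Going by these compounds, it remains open whether a group other than a halogen, such as a nitrile or a trifluoromethyl group, would leave clearance within the scatter on this aromatic carbon. The compounds shown also do not separate the contributions of the several places in which compound 1 differs from compound 2.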